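Swapping a hydroxy for a carbamoyl on the piperidine

A few compounds are considered here, and "the series" means these few. Any claim that something is new, unique, unknown or untested is made for them only; others in the source may bear on it.

Of the compounds shown here, two have been measured in an assay on HEK293 cells for displacement of a labelled ligand from NPC1-like intracellular cholesterol transporter 1 (Homo sapiens); on this read-out lower numbers stand for stronger inhibition and higher numbers for weaker inhibition. Compound 1 `CC(C)(C)OC(=O)NCCCNC(=O)CN1CN(c2ccccc2)C2(CCN(C(=O)c3ccc(C4CCCCC4)cc3)CC2)C1=O` gives 6000 nM. Compound 2 `CC(C)(C)c1ccc(C(=O)N2CCC3(CC2)C(=O)N(CC(=O)N2CCCC(O)C2)CN3c2ccccc2)cc1` gives 12200 nM; of the two numbers, that of compound 2 is the higher, and its gap to compound 1 lies beyond the usual scatter, so compound 2 is the weaker inhibitor of the pair.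

Compound 3 `CC(C)(C)c1ccc(C(=O)N2CCC3(CC2)C(=O)N(CC(=O)N2CCCC(C(N)=O)C2)CN3c2ccccc2)cc1` has not yet been measured. It differs from compound 2 in one place: carbamoyl in place of hydroxy on a saturated ring carbon. Among the measured compounds shown here, no measured pair shows what this particular swap does, so the expectation for compound 3 rests only on where compound 2 stands. The group that leaves and the group that enters each bring one hydrogen-bond donor and one hydrogen-bond acceptor, which gives no ground for a large step in either direction in this assay. Compound 3 is therefore expected to give about 10000 nM, with a likely range from 3500 nM to 30000 nM. The estimated step of a 1.2-fold lower number from compound 2 to compound 3 (0.09 log units; within the scatter) is expected to stay within the scatter.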

Compound 3, half-maximal inhibitory concentration: 16900 nM
For compound 3 the middle estimate is 1.7-fold (0.23 log units) below the measured one, within the range that was stated.
By their numbers in this assay, from the lowest: compound 1; then compounds 2 and 3 (each within the scatter of the next).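

In this assay, carbamoyl in place of hydroxy on this saturated ring carbon, two ring bonds from the ring nitrogen, gives a 1.4-fold higher number from compound 2 to compound 3 (0.14 log units; within the scatter), so the two compounds cannot be told apart. Among the compounds shown here, this is the first measured swap at this position, and it shows that a group of three heavy atoms and a group of one heavy atom, each with one hydrogen-bond donor and one acceptor, read alike here. Compound 1 differs from both in more than one place, so it adds nothing about this position.

On these data alone, whether an amine, a carboxylic acid or a longer chain on the same ring carbon would move the number beyond the scatter remains open. The data shown also offer no measurement that speaks to why hydroxy and carbamoyl read alike.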